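One Methyl More: Two Steps Compared

The source may hold more compounds than are shown below. What is called first, only, known or untested is meant among the compounds shown, and "the series" means these compounds.

Of the compounds shown here, three have so far been measured in a functional assay on the whole organism (blood, strain Wistar-Okamoto) with Rattus norvegicus as the target, with a stated time of 5 days; a higher number here means that more compound is needed for the effect, a lower number that less compound is needed. Compound 1, `CCC/N=C(\NC#N)Nc1cccnc1`, gives 20 mg/kg. Compound 2, `CCC(C)/N=C(\NC#N)Nc1cccnc1`, gives 20 mg/kg. Compound 3, `CC(C)C(C)(C)/N=C(\NC#N)Nc1ccncc1`, gives 20 mg/kg. All three values sit level with one another within the usual scatter, so none of them can be called stronger or weaker than another.

Compound 2 differs from compound 1 by a single change: methyl in place of hydrogen on a saturated chain carbon bound to a double-bonded nitrogen and a saturated chain carbon. This change produced no change at the digits printed from compound 1 to compound 2 (within the scatter). Compound 3 is built on another core, and the difference between the core of compound 3 and the core of compound 1 is not broken down here.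

Compound 4, `CC(C)(C)C(C)(C)/N=C(\NC#N)Nc1ccncc1`, has not yet been measured in this assay. It differs from compound 3 as follows: methyl in place of hydrogen on a saturated chain carbon bound to three saturated chain carbons. For the measured compounds named here, this is the same kind of change as the one from compound 1 to compound 2, but not the same: in the earlier pair the carbon receiving the methyl was bound to a double-bonded nitrogen and a saturated chain carbon, whereas in compound 4 it is bound to three saturated chain carbons.

The step expected here is no change at the digits printed from compound 3 to compound 4 (within the scatter), because no change at the digits printed from compound 1 to compound 2 (within the scatter) suggests that one added methyl on this chain leaves the dose where it was. Compound 4 is therefore estimated at 20 mg/kg, most likely falling between 10 mg/kg and 40 mg/kg.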

Compound 4, minimum effective dose: 20 mg/kg
Compound 4: the middle estimate sits on the measured number at the digits printed; measured number inside the range.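

Adding one methyl, which turns isopropyl into tert-butyl on a saturated chain carbon bound to three saturated chain carbons, gives no change at the digits printed from compound 3 to compound 4 (within the scatter) in this assay. Set beside the earlier step on the other core, the two steps agree: the same change on two cores in this assay, no change at the digits printed (within the scatter) from compound 1 to compound 2 and no change at the digits printed (within the scatter) from compound 3 to compound 4, 1.0-fold (0.00 log units) apart, within the scatter of two such steps. In these two pairs, then, a single added methyl leaves the minimum effective dose level on either core, but two pairs are a small sample, the methyl lands on a differently bound carbon in each, and a level result does not explain why the dose stays where it is, so this does not show that the change would carry over to every core in the series.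

All four compounds stand at the same printed dose, so the compounds shown leave open what, if anything, on this chain would move the dose in either direction. A longer chain, or an amine or a carboxylic acid in place of the added methyl, would be a much larger change at this spot and would test whether the dose stays level beyond a single methyl.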